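This account rests on a few compounds, and the source may have more. Where it says the series, first, only, none or still open, it means among the compounds named here.

Measured in a functional assay on VCaP cells (Homo sapiens) for antiproliferative activity, read by CCK-8 assay, with a stated time of 6 days; on this read-out lower numbers stand for stronger inhibition and higher numbers for weaker inhibition:
compound 1 `N#Cc1ccc(N2CCc3cc(-c4cncnc4)ccc32)cc1C(F)(F)F` — "not determined" (no result reported)
compound 2 `CCN(c1ccc(C#N)c(Cl)c1)c1cc(-n2cnc3ccccc32)ccc1C` — 8560 nM
compound 3 `N#Cc1ccc(N2CCc3cc(-c4cnc5ccccc5c4)ccc3C2)cc1C(F)(F)F` — > 30000 nM

Going by the values given here, compound 2 is the only compound of the three with a numerical result in this assay, 8560 nM. Compound 1 has no reported result. For compound 3 the value > 30000 nM is a limit of this assay, not a number, and it is the entry described by the limit of > 30000 nM in this assay, at which 1 of the 3 values shown sits. Among the compounds with values here, no two measured compounds differ in one place only, so no measured step can be drawn; compound 2 stands alone as the reference point for any change.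

Compound 4 `CCN(c1ccc(C#N)c(Cl)c1)c1cc(-n2ccnc2)ccc1C` is not yet measured. Compared with compound 2 it differs as follows: 1H-imidazol-1-yl in place of 1H-benzimidazol-1-yl on an aromatic carbon. The replacement keeps the five-membered aromatic ring with two hetero atoms and the two hydrogen-bond acceptors while removing the fused six-membered carbon ring, and the group keeps its place para to the methyl group and meta to the large group.

Within the data shown here, with no measured step to lean on, and with compound 2 already weak at 8560 nM, the expectation for this assay is a modest loss, a step from compound 2 to compound 4 of about a 1.5-fold higher number from compound 2 to compound 4 (0.18 log units; within the scatter), which may or may not exceed the scatter. Compound 4 is therefore estimated at 13000 nM, within the range 4500 nM to 30000 nM, with a real chance that only a limit is reported.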

Compound 4, half-maximal inhibitory concentration: > 30000 nM
Compound 4 ended at the assay's limit; the forecaster's own chance of this, stated with the estimate: 30%; middle value at least 2.3-fold (0.36 log units) from the limit.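

In this assay the series now has its first measured step: on the aromatic carbon para to a methyl group, 1H-imidazol-1-yl in place of 1H-benzimidazol-1-yl gives an at least 3.5-fold higher number from compound 2 to compound 4 (0.54 log units; beyond the scatter). With the five-membered aromatic ring and the count of hydrogen-bond acceptors unchanged, the fused six-membered carbon ring is the part that differs in this pair, and its removal goes with a loss of measurable activity at this position. For compound 4 the value > 30000 nM is a limit of the assay and not a number, so the true size of the step stays unknown, and compound 4 adds to the entries at that limit: the limit of > 30000 nM in this assay, at which 2 of the 4 values shown sit.

Open, on these data alone, is whether an amine, a morpholine ring or a carboxylic acid on this same carbon would give a number in this assay, and how it would compare with compound 2 at 8560 nM. Also open, as far as these compounds go, is whether the fused carbon ring counts in the same way on the cores of compound 1 and compound 3.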